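The source may report more compounds than this note shows. Statements on the series, on what has been measured and on what is new or still open speak of the compounds shown alone.

Measured compounds:
Compound 1 `COc1ccc(Sc2nc3cc(N)cc(N)c3nc2-c2ccccc2)cc1`: in a functional assay on UO-31 cells (Homo sapiens) for inhibition, read by sulforhodamine B assay, with a stated time of 48 h (on this read-out higher numbers stand for lower toxicity in this test and lower numbers for higher toxicity in this test), compound 1 gives < 100000 nM, which is a limit of the assay.
Compound 2 `Nc1cc(N)c2nc(-c3ccccc3)c(Oc3ccc(F)cc3)nc2c1`: in this assay compound 2 gives < 100000 nM, again a limit and not a number.

Among the compounds with values here, compound 2 therefore stands only at a limit, and the sole measured step, a step that the two limits leave unreadable from compound 1 to compound 2, cannot be read in size or direction (the limit of < 100000 nM in this assay, at which 2 of the 2 values shown sit). Compound 3 `Nc1cc(N)c2nc(-c3ccccc3)c(Sc3ccc(F)cc3)nc2c1` is the next member: (4-fluorophenyl)sulfanyl in place of 4-fluorophenoxy on an aromatic carbon. Within the data shown here, the only step that bears on this change is the unreadable one from compound 1 to compound 2, which exchanged the same position; it gives no readable size, so no shift beyond the scatter in this assay can be argued in either direction. Compound 3 is expected to sit at the same limit, with an estimate of 100000 nM, range 30000 nM to 100000 nM, and an expected step of a number no lower from compound 2 to compound 3 (the limit leaves the size open).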

Compound 3, concentration lethal to 50% of the cells: < 100000 nM
Compound 3: a limit, no number (the forecaster's own chance of this, stated with the estimate: 80%); the middle value sits exactly at the limit.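

Compound 3 yields no readable step against compound 1 or compound 2, as all three give a limit and not a number: the limit of < 100000 nM in this assay, at which 3 of the 3 values shown sit. In this assay the compounds shown leave open the size and direction of each of these exchanges on the shared core.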